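A few compounds are considered here, and "the series" means these few. Any claim that something is new, unique, unknown or untested is made for them only; others in the source may bear on it.

In an assay on HeLa cells for inhibition of Kinesin-like protein KIF15 (Homo sapiens), read by microscopy, with stated times of 2 s and 20 s, tested at 750 nM (a higher number here means more inhibition at the concentration tested (going by the name of the read-out), a lower number less inhibition), the measured compounds stand as follows:

compound 1 `O=C1Nc2ccc(C(=O)c3ccco3)cc2/C1=C/c1cc(F)c(O)c(Br)c1`: 38%
compound 2 `O=C1Nc2ccc(C(=O)c3ccco3)cc2/C1=C/c1cc(Br)cc(Br)c1`: 16%
compound 3 `O=C1Nc2ccc(C(=O)c3ccco3)cc2/C1=C/c1ccc(O)c(C(F)(F)F)c1`: 9.5%

Compound 2 holds the second highest of the three numbers; its nearest neighbour is compound 3, within the scatter, while the gap to compound 1 is beyond the scatter.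

Compound 4 `COc1ccc(/C=C2\C(=O)Nc3ccc(C(=O)c4ccco4)cc32)cc1Br` differs from compound 2 by 3-bromo-4-methoxyphenyl in place of 3,5-dibromophenyl on a double-bonded chain carbon bound to a double-bonded ring carbon.

One recorded step bears on this change, a number 22 percentage points lower from compound 1 to compound 2 (beyond the scatter), where a ring carrying a hydroxy group gave way to the dibromo ring and the number fell by a modest amount. Compound 4 returns an oxygen to the ring, as methoxy rather than hydroxy, and drops one bromine, so a partial recovery toward compound 1 is expected, of uncertain size: the expected step is a number 6 percentage points higher from compound 2 to compound 4 (within the scatter). Compound 4 is estimated at 22%, in the range 8% to 40%.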

Compound 4, a percentage reported as inhibition, at one concentration (the size of the read-out at that concentration, not a potency): 2.3%
Beside the measured number, compound 4's estimate is 19.7 percentage points above it, outside the stated range (below it).
By their numbers in this assay, from the lowest: compounds 4, 3 and 2 (each within the scatter of the next, the first and the last beyond it); then compound 1.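

In this assay, putting 3-bromo-4-methoxyphenyl on the double-bonded chain carbon in place of 3,5-dibromophenyl gives a number 13.7 percentage points lower from compound 2 to compound 4 (beyond the scatter), so a ring oxygen present as methoxy does not restore the number. Exchanging the fluorinated hydroxy ring for the same 3-bromo-4-methoxyphenyl group gives a number 35.7 percentage points lower from compound 1 to compound 4 (beyond the scatter), which shows that ring oxygen alone does not account for the higher number. Nothing at hand explains either step. Still open, on these data alone, is whether the free hydroxy group, the fluorine or their combination carries the higher number. Also open, as far as these compounds go, is how an amine or a carboxylic acid on this ring would read.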